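Aryl diyne alcohols: methylsulfanyl to trifluoromethyl swap

This account rests on a few compounds, and the source may have more. Where it says the series, first, only, none or still open, it means among the compounds named here.

Measured compounds:
compound 1 `COc1ccccc1C#Cc1ccccc1C#CCCCCO`: 1000 nM
compound 2 `CSc1ccccc1C#Cc1ccccc1C#CCCCCO`: 3500 nM

Both were run in a functional assay on SR cells (Homo sapiens) for cytotoxicity; a lower number here means a stronger inhibitor of growth, a higher number a weaker inhibitor of growth. Compound 2 stands with the highest of the two numbers; its nearest neighbour is compound 1, and the step of a 3.5-fold higher number from compound 1 to compound 2 (0.54 log units; beyond the scatter) lies beyond the scatter, so compound 2 is the weaker growth inhibitor of the pair.

Compound 3 `OCCCCC#Cc1ccccc1C#Cc1ccccc1C(F)(F)F` is not yet measured. It differs from compound 2 by trifluoromethyl in place of methylsulfanyl on an aromatic carbon; the place is on an aromatic carbon of a six-membered aromatic ring of carbon only, ortho to a large group. Within the data shown here, no measured step exchanges methylsulfanyl for trifluoromethyl. Among the measured compounds shown here, the only step in hand, a 3.5-fold higher number from compound 1 to compound 2 (0.54 log units; beyond the scatter), concerns the same position and was modest; it shows that a change of the group at this position moves the number, but does not show the direction for trifluoromethyl. A step of modest size in either direction, or none beyond the scatter, is therefore expected in this assay, and the range is set wide.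

On that basis compound 3 is estimated at 3000 nM, with a range from 1000 nM to 10000 nM, which means an expected step of a 1.2-fold lower number from compound 2 to compound 3 (0.07 log units; within the scatter).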

Compound 3, concentration for 50% growth inhibition: 400 nM
The estimate for compound 3 lay 7.5-fold (0.88 log units) above the measured number, outside the stated range (below it).
By their numbers in this assay, from the lowest: compound 3; then compound 1; then compound 2.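

The position on the aromatic carbon ortho to a large group can move the number down as well as up: in this assay trifluoromethyl gives an 8.8-fold lower number from compound 2 to compound 3 (0.94 log units; beyond the scatter) and also a 2.5-fold lower number from compound 1 to compound 3 (0.40 log units; beyond the scatter), whereas the earlier pair showed only a rise. Both steps lie beyond the scatter, so compound 3 is the strongest growth inhibitor of the three, and the order at this position runs trifluoromethyl, then methoxy, then methylsulfanyl. The swap from methylsulfanyl to trifluoromethyl changes the heavy-atom count and removes the one hydrogen-bond acceptor of the leaving group, but no measurement at hand bears on what lies behind these steps.

As far as these compounds go, it remains open whether a chlorine atom, an amine or a carboxylic acid at this position would fall with trifluoromethyl or with methylsulfanyl. From the compounds shown here alone, it is equally open whether the same order of the three groups would hold if the hydroxyl-ending chain on the shared core were replaced by a longer chain, or in cells other than those of this assay.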